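A few compounds are considered here, and "the series" means these few. Any claim that something is new, unique, unknown or untested is made for them only; others in the source may bear on it.

Working notes on the series. Compound 1 `CSCC[C@H](NC(=O)c1ccc(NCc2cncn2Cc2ccccc2C)cc1-c1ccccc1)C(=O)O`, compound 2 `CCOC(=O)[C@H](CCSC)NC(=O)c1ccc(CNCc2c[nH]cn2)cc1-c1ccccc1C` and compound 3 `COC(=O)[C@H](CCSC)NC(=O)c1ccc(NCc2cncn2Cc2cccc(C)c2)cc1-c1ccccc1` have been run in a functional assay on NIH3T3 cells (Mus musculus); a lower number here means that less compound is needed, a higher number that more compound is needed for the effect. For the measured compounds named here, compound 2 gives 10 uM in this assay, the only value that is a number. For compound 1 this assay reports > 10 uM, which is a limit of the assay and not a number. For compound 3 this assay reports > 10 uM, again a limit. Compound 2 thus stands alone with a measured number, while the other two sit at the limit of > 10 uM in this assay, at which 2 of the 3 values shown sit. Going by the values given here, no two measured compounds differ in a single place, so no measured step is available to guide the next compound.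

Compound 4 `CSCC[C@H](NC(=O)c1ccc(CNCc2c[nH]cn2)cc1-c1ccccc1C)C(=O)OC(C)C` differs from compound 2 by methyl in place of hydrogen on a saturated chain carbon bound to an oxygen next to a carbonyl group and a saturated chain carbon, that is ethoxycarbonyl to isopropoxycarbonyl. Among the compounds with values here, with no measured step of this kind to draw on, the change is expected to read no change at the digits printed from compound 2 to compound 4 (within the scatter), none beyond the scatter. Compound 4 is therefore expected to give about 10 uM in this assay, with a range from 4 uM to 25 uM.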

Compound 4, concentration for half-maximal effect: 10 uM
Compound 4: middle estimate and measured number agree at the digits printed; the range from low to high includes it.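

For the compounds shown here, this is the first step that can be read: exchanging ethoxycarbonyl for isopropoxycarbonyl gives no change at the digits printed from compound 2 to compound 4 (within the scatter) in this assay. Methyl in place of hydrogen on the saturated chain carbon bound to the oxygen therefore produces no step beyond the scatter at this place, on the core of compound 2. This single step covers only this one added methyl on this core, and the remaining values offer no number for comparison: the limit of > 10 uM in this assay, at which 2 of the 4 values shown sit.

Still open, as far as these compounds go, is whether a tert-butoxycarbonyl group or a primary amide at this place would give a step beyond the scatter on the core of compound 2. Also open, from the compounds shown here alone, is how a carboxylic acid at this place would compare with these two esters on that same core.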